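This account rests on a few compounds, and the source may have more. Where it says the series, first, only, none or still open, it means among the compounds named here.

Compound 1 `CCCCSc1nsnc1C1CN2CCC[C@H]1C2` gives 0.045 mg/kg in a functional assay on the whole organism for inhibition, with Mus musculus as the target; a lower number here means that less compound is needed, a higher number that more compound is needed for the effect. Compound 2 `CCCCSc1nsnc1[C@H]1CN2CCC[C@@H]1C2` gives 0.012 mg/kg in this assay. Compound 3 `CCCSc1nsnc1C1CN2CCC[C@H]1C2` gives 0.056 mg/kg in this assay.

Compound 3 stands highest of the three numbers in this assay; its nearest neighbour is compound 1, within the scatter, and its furthest is compound 2, beyond the scatter. Compound 4 `CCCSc1nsnc1[C@H]1CN2CCC[C@@H]1C2` differs from compound 3 in this way: the two compounds have the same atoms and bonds; at least one stereo element is drawn with a configuration in one of them and without one in the other: 2 of 3 stereo elements differ; a stereocentre at a saturated ring carbon is drawn without a configuration in compound 3 and R in compound 4; a stereocentre at a saturated ring carbon is drawn R in compound 3 and S in compound 4. For the measured compounds named here, one measured step bears directly on this change, a 3.8-fold lower number from compound 1 to compound 2 (0.57 log units; beyond the scatter), where the same two stereocentres pass from the pattern of compound 1 to that of compound 2 and the number drops by a modest amount beyond the scatter; the relevant observation is the fact that one of compounds 1 and 2 is drawn with a defined configuration and the other without, at the place where they differ. The other measured step, a 1.2-fold higher number from compound 1 to compound 3 (0.09 log units; within the scatter), concerns only the chain and lies within the scatter, so the chain of compound 3 gives no reason to expect the stereochemical step to behave differently here. The step to compound 4 is therefore expected to lower the number by roughly the same amount, a 3.7-fold lower number from compound 3 to compound 4 (0.57 log units; beyond the scatter). Compound 4 is accordingly estimated at 0.015 mg/kg in this assay, with a range from 0.007 mg/kg to 0.032 mg/kg.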

Compound 4, dose for half-maximal effect: 0.021 mg/kg
Compound 4: middle estimate off by 1.4-fold (0.15 log units), on the low side, within the range that was stated.
By their numbers in this assay, from the lowest: compounds 2 and 4 (each within the scatter of the next); then compounds 1 and 3 (each within the scatter of the next).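

With compound 4, the stereochemical change in this assay is now seen on a second chain, and the number falls again (in a 2.7-fold lower number from compound 3 to compound 4 (0.43 log units; beyond the scatter)), in the same direction as on the first pair (in a 3.8-fold lower number from compound 1 to compound 2 (0.57 log units; beyond the scatter)). The change of hydrogen in place of methyl on a saturated chain carbon, three bonds along the chain from a sulfur, can now also be read between two compounds with a fully drawn configuration (in a 1.8-fold higher number from compound 2 to compound 4 (0.24 log units; within the scatter)), and in both pairs it stays within the scatter: the same change on two cores in this assay, a 1.2-fold higher number (0.09 log units; within the scatter) from compound 1 to compound 3 and a 1.8-fold higher number (0.24 log units; within the scatter) from compound 2 to compound 4, 1.4-fold (0.15 log units) apart, within the scatter of two such steps. The stereochemical step is still not a comparison of one fully drawn configuration with another, because one partner has a centre without a drawn configuration: the fact that one of compounds 3 and 4 is drawn with a defined configuration and the other without, at the place where they differ.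

The compounds shown leave open how the mirror-image configuration, drawn in full at both stereocentres, would stand in this assay on either chain. They also leave open whether a hexyl chain or a benzyl group on the sulfur would keep the number in the range seen here.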